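The compounds below may be only part of what the source reports. "The series", "measured", "known", "first", "only" and "open" are said of these compounds alone.

Measured so far:
compound 1, `COCCOC(=O)C1=C(C)NC(C)=C(C(=O)OCCOC)C1c1cnc(SC)n1Nc1ccccc1`: 17.9 nM
compound 2, `CSc1ncc(C2C(C(=O)OC3CCCCC3)=C(C)NC(C)=C2C(=O)OC2CCCCC2)n1Nc1ccccc1`: 465 nM
compound 3, `COC(=O)C1=C(C)NC(C)=C(C(=O)OC)C1c1cnc(SC)n1Nc1ccccc1`: 3.54 nM

In an assay on isolated protein (strain albino) for antagonist activity at Voltage-dependent L-type calcium channel subunit alpha-1C (Cavia porcellus) (on this read-out lower numbers stand for stronger inhibition and higher numbers for weaker inhibition), compound 3 gives the lowest number of the three and is therefore the strongest inhibitor here. Compound 1 gives a higher number, and that gap lies beyond the usual scatter; compound 2 gives a much higher number still. In both of those compounds the two methyl esters of compound 3 are replaced by other groups.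

Compound 4, `COC(=O)C1=C(C)NC(C)=C(C(=O)OCCCc2ccccc2)C1c1cnc(SC)n1Nc1ccccc1`, keeps one methyl ester and changes the other: phenethyl in place of hydrogen on a saturated chain carbon bound to an oxygen next to a carbonyl group. Within the data shown here, since compounds 1 and 2 both gave higher numbers than compound 3, some loss is expected here too, though only one ester changes. The expected step of a 2.8-fold higher number from compound 3 to compound 4 (0.45 log units; beyond the scatter) is a modest weakening, beyond the scatter. Compound 4 is estimated at 10 nM, within a range of 3 nM to 40 nM.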

Compound 4, half-maximal inhibitory concentration: 3.05 nM
Compound 4: middle estimate off by 3.3-fold (0.52 log units), on the high side; low and high end bracket the measured number.
By their numbers in this assay, from the lowest: compounds 4 and 3 (each within the scatter of the next); then compound 1; then compound 2.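

In this assay, putting (3-phenylpropoxy)carbonyl in place of one methoxycarbonyl gives a 1.2-fold lower number from compound 3 to compound 4 (0.06 log units; within the scatter), so the two numbers cannot be told apart. Among these compounds, compound 1 and compound 2 carry other groups on both esters, so this pair is the first to isolate a single ester, and it shows that this position accommodates a 3-phenylpropyl chain with its aromatic ring. Nothing measured here explains that result. On these data alone, it remains open whether an ethyl group, or a chain bearing an amine or a carboxylic acid, would give a similar number in place of 3-phenylpropyl.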